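This account rests on a few compounds, and the source may have more. Where it says the series, first, only, none or still open, it means among the compounds named here.

In a functional assay on HeLa cells (Homo sapiens) for antiproliferative activity, read by cell counting, with a stated time of 2 days (on this read-out higher numbers stand for weaker inhibition and lower numbers for stronger inhibition), compound 1, with the structure `COc1cc(C(=O)c2sc(Nc3ccccc3)nc2N)cc(OC)c1OC`, gives 14 nM. Compound 2, with the structure `COc1ccc(C(=O)c2sc(Nc3ccccc3)nc2N)cc1OC`, gives 6000 nM in this assay. The two differ by hydrogen in place of methoxy on an aromatic carbon, and that one change produced a 430-fold higher number from compound 1 to compound 2 (2.63 log units; beyond the scatter), so taking away a methoxy group at that place left a much weaker compound.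

Compound 3 has the structure `COc1ccc(C(=O)c2sc(Nc3ccc(Cl)cc3)nc2N)cc1`. In this assay compound 3 reaches only a limit of the measurement, > 10000 nM. Compound 3 differs from compound 1 in more than one place, and the difference between the two cores is not broken down here.

Compound 4, with the structure `Nc1nc(Nc2ccc(Cl)cc2)sc1C(=O)c1ccccc1`, has not yet been measured. It differs from compound 3 by hydrogen in place of methoxy on an aromatic carbon. Within the data shown here, this is the same kind of change as the one from compound 1 to compound 2, though not the same: in compound 1 the methoxy that leaves is ortho to a methoxy group, meta to a large group and meta to a methoxy group, whereas in compound 3 it is para to a large group.

The expected step that the limit leaves unreadable from compound 3 to compound 4 cannot be told as a number, since compound 3 only sets a limit, (the limit of > 10000 nM in this assay, at which 1 of the 3 values shown sits). Compound 4 is expected to come out around 30000 nM, most probably again only as a limit. That expectation rests on the direction of a 430-fold higher number from compound 1 to compound 2 (2.63 log units; beyond the scatter), where removing a methoxy made the number larger.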

Compound 4, half-maximal inhibitory concentration: > 10000 nM
Compound 4 was reported as a limit; the forecaster's own chance of this, stated with the estimate: 85%; the middle value does not contradict the limit.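

Compound 3 and compound 4 are both reported only as limits, not as numbers, so no step between them can be read: the limit of > 10000 nM in this assay, at which 2 of the 4 values shown sit.

The compounds shown leave open how the change from 4-methoxyphenyl to phenyl affects activity in compound 3 and compound 4, and whether it resembles the loss of a methoxy group seen between compound 1 and compound 2.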